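Title: Aryl ether substituents and agonist potency at the receptor

The source may hold more compounds than are shown below. What is called first, only, known or untested is meant among the compounds shown, and "the series" means these compounds.

The measured compounds:
Compound 1 `Cc1ccccc1Oc1ccc(N2CCC[C@H]2CC(=O)O)cc1` — 5600 nM
Compound 2 `CCOc1ccccc1Oc1ccc(N2CCC[C@H]2CC(=O)O)cc1` — > 33000 nM
Compound 3 `CC(C)(C)c1ccccc1Oc1ccc(N2CCC[C@H]2CC(=O)O)cc1` — > 17000 nM

Within the data shown here, in a functional assay on cells for agonist activity at Free fatty acid receptor 1 (Mus musculus), read by FLIPR and calcium flux, with a stated time of 100 s (a higher number here means that more compound is needed for the effect, a lower number that less compound is needed), compound 1 gives 5600 nM, the only firm number among the three. For compound 2 this assay reports only a limit, > 33000 nM. For compound 3 it likewise reports only a limit, > 17000 nM, so compound 3 stands at the weak end of what is shown, with no exact number of its own.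

Compound 4 `O=C(O)C[C@@H]1CCCN1c1ccc(Oc2ccccc2-c2ccccc2)cc1` differs from compound 3 by phenyl in place of tert-butyl on an aromatic carbon. Among the measured compounds shown here, two measured steps bear on this: an at least 5.8-fold higher number from compound 1 to compound 2 (0.77 log units; beyond the scatter) and an at least 3.0-fold higher number from compound 1 to compound 3 (0.48 log units; beyond the scatter). Both enlargements of the methyl raised the number beyond the scatter, and the tert-butyl to phenyl change enlarges the group again, though the step from compound 2 to compound 3 could not be read because both sit at limits. Compound 4 is therefore expected to remain weak, with a step that the limit leaves unreadable from compound 3 to compound 4 estimated as no step beyond the scatter or a small further rise. For compound 4 the estimate in this assay is 25000 nM, with a range from 6000 nM to 80000 nM.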

Compound 4, half-maximal effective concentration: 1300 nM
Compound 4: middle estimate off by 19-fold (1.28 log units), on the high side; the whole stated range lies above it.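

In this assay, phenyl on this aromatic carbon, ortho to a large group, goes the other way from ethoxy and tert-butyl, with a 4.3-fold lower number from compound 1 to compound 4 (0.63 log units; beyond the scatter), so a group larger than methyl does not always raise the number, and only compound 2 and compound 3 show that rise. Against tert-butyl, phenyl gives an at least 13-fold lower number from compound 3 to compound 4 (1.11 log units; beyond the scatter), a minimum size set by a limit for compound 3: the limit of > 17000 nM in this assay, at which 1 of the 4 values shown sits. Against ethoxy, phenyl gives an at least 25-fold lower number from compound 2 to compound 4 (1.40 log units; beyond the scatter), likewise a minimum size set by a limit for compound 2: the limit of > 33000 nM in this assay, at which 1 of the 4 values shown sits.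

The compounds shown leave open whether a pyridine ring or a phenyl carrying a methoxy group at this place would keep the lower number. The step between compound 2 and compound 3 cannot be read, with both standing at limits.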